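This account rests on a few compounds, and the source may have more. Where it says the series, first, only, none or still open, it means among the compounds named here.

Working notes on the series. Compound 1 `O=C(/C=C/c1cccs1)Nc1ccc2ncnc(Nc3cccc(Br)c3)c2c1` gives 2.51 ug/mL in a functional assay on B16-F10 cells (Mus musculus) for inhibition, read by MTT assay, with a stated time of 48 h; on this read-out lower numbers stand for stronger inhibition and higher numbers for weaker inhibition. Compound 2 `Cc1ccc(/C=C/C(=O)Nc2ccc3ncnc(Nc4cccc(Br)c4)c3c2)cc1` gives 1.39 ug/mL in this assay; the change between these two is 4-methylphenyl in place of thiophen-2-yl on a double-bonded chain carbon bound to a double-bonded chain carbon and it made a step of a 1.8-fold lower number from compound 1 to compound 2 (0.26 log units; within the scatter). Compound 3 `O=C(/C=C/c1cccs1)Nc1ccc2ncnc(Nc3cccc(Cl)c3)c2c1` gives 4.26 ug/mL in this assay; its core differs from that of compound 1 by chloro in place of bromo on an aromatic carbon, a step of a 1.7-fold higher number from compound 1 to compound 3 (0.23 log units; within the scatter). Compound 4 `Cc1ccc(/C=C/C(=O)Nc2ccc3ncnc(Nc4cccc(Cl)c4)c3c2)cc1` is not yet measured. It differs from compound 3 by 4-methylphenyl in place of thiophen-2-yl on a double-bonded chain carbon bound to a double-bonded chain carbon, the same change as that from compound 1 to compound 2, at a place described in the same words. Because the same change gave a 1.8-fold lower number from compound 1 to compound 2 (0.26 log units; within the scatter), the expected step is a 1.8-fold lower number from compound 3 to compound 4 (0.25 log units; within the scatter). Compound 4 is thus estimated at 2.4 ug/mL, with a likely range from 1.2 ug/mL to 4.8 ug/mL.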

Compound 4, half-maximal inhibitory concentration: 2.02 ug/mL
The estimate for compound 4 lay 1.2-fold (0.07 log units) above the measured number; the range from low to high includes it.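

In this assay, 4-methylphenyl in place of thiophen-2-yl gives a 2.1-fold lower number from compound 3 to compound 4 (0.32 log units; beyond the scatter), and this step agrees with the one seen on the core of compound 1: the same change on two cores in this assay, a 1.8-fold lower number (0.26 log units; within the scatter) from compound 1 to compound 2 and a 2.1-fold lower number (0.32 log units; beyond the scatter) from compound 3 to compound 4, 1.2-fold (0.07 log units) apart, within the scatter of two such steps. Chloro in place of bromo gives a 1.5-fold higher number from compound 2 to compound 4 (0.16 log units; within the scatter), and this step also agrees with its earlier counterpart: the same change on two cores in this assay, a 1.7-fold higher number (0.23 log units; within the scatter) from compound 1 to compound 3 and a 1.5-fold higher number (0.16 log units; within the scatter) from compound 2 to compound 4, 1.2-fold (0.07 log units) apart, within the scatter of two such steps. Each change therefore carried over between the two cores shown here, but these four compounds give only two instances of each change, and this does not show that either change would transfer to other cores in the series.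

Still open, as far as these compounds go, is how an amine or a carboxylic acid in place of 4-methylphenyl would read in this assay. Also open, from the compounds shown here alone, is how fluoro in place of chloro would read there.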